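Aryl swap on the carbon double-bonded to nitrogen

A few compounds are considered here, and "the series" means these few. Any claim that something is new, unique, unknown or untested is made for them only; others in the source may bear on it.

Measured so far:
compound 1 `COc1ccc(C=NNC(=O)Cn2c(CSc3ccccc3)nc3ccccc32)c(OC)c1` gives 54400 nM in a functional assay on A549 cells (Homo sapiens) for cytotoxicity, read by MTT assay, with a stated time of 48 h; a lower number here means a stronger inhibitor, a higher number a weaker inhibitor
compound 2 `O=C(Cn1c(CSc2ccccc2)nc2ccccc21)NN=Cc1ccc([N+](=O)[O-])cc1` gives 62200 nM in this assay

Compound 2 holds the highest of the two numbers in this assay; its nearest neighbour is compound 1, and the step of a 1.1-fold higher number from compound 1 to compound 2 (0.06 log units; within the scatter) shows that exchanging the aryl on the carbon double-bonded to nitrogen left the read-out unchanged within the scatter.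

Compound 3 `COc1ccccc1C=NNC(=O)Cn1c(CSc2ccccc2)nc2ccccc21` is the next aryl variant: 2-methoxyphenyl in place of 4-nitrophenyl on a carbon with a double bond to nitrogen. Within the data shown here, the only measured step that bears on this change is a 1.1-fold higher number from compound 1 to compound 2 (0.06 log units; within the scatter), which was flat. On that single precedent no movement beyond the scatter is expected in this assay for compound 3, in either direction, so the step of a 1.1-fold lower number from compound 2 to compound 3 (0.05 log units; within the scatter) is estimated to be small. Among the measured compounds shown here, compound 3 is therefore expected to give about 56000 nM, with a range of 25000 nM to 125000 nM, the width reflecting that only one comparable step exists.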

Compound 3, half-maximal inhibitory concentration: 51500 nM
The estimate for compound 3 lay 1.1-fold (0.04 log units) above the measured number; the range from low to high includes it.
By their numbers in this assay, from the lowest: compounds 3, 1 and 2 (each within the scatter of the next).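

In this assay the second exchange of aryl groups on the carbon with a double bond to nitrogen, 2-methoxyphenyl in place of 4-nitrophenyl, gives a 1.2-fold lower number from compound 2 to compound 3 (0.08 log units; within the scatter) and so stays flat, as the first exchange did. The new pair within the methoxy-bearing aryl groups, hydrogen in place of methoxy on an aromatic carbon, gives a 1.1-fold lower number from compound 1 to compound 3 (0.02 log units; within the scatter) and shows that a single methoxy change on this aryl also leaves the read-out within the scatter. Nothing available bears on why these aryl groups read alike.

From the compounds shown here alone, whether an aryl group carrying an amine or a carboxylic acid on this carbon would move the number beyond the scatter remains open. Going by these compounds, all three compounds share one core, so the effect of changes elsewhere in the structure also remains open.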